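Series notes: methyl branching on the alkyl arm and clearance

The source may report more compounds than this note shows. Statements on the series, on what has been measured and on what is new or still open speak of the compounds shown alone.

Measured compounds:
- compound 1, `CCc1nc2nc(C)cc(Nc3ccc(Cl)cc3)n2n1`: 12.8 mL.min-1.g-1
- compound 2, `Cc1cc(Nc2ccc(S(F)(F)(F)(F)F)cc2)n2nc(C(C)(F)F)nc2n1`: a limit of the assay, < 5 mL.min-1.g-1
- compound 3, `CCC(F)(F)c1nc2nc(C)cc(Nc3ccc(S(F)(F)(F)(F)F)cc3)n2n1`: a limit of the assay, < 5 mL.min-1.g-1

Within the data shown here, in an in vitro ADME assay on microsomes from liver (Homo sapiens) for metabolic stability (on this read-out lower numbers stand for slow clearance and higher numbers for fast clearance), compound 1 gives 12.8 mL.min-1.g-1, the only number in the set. Compound 2 gives only a limit of the assay, < 5 mL.min-1.g-1. Compound 3 also gives only a limit, < 5 mL.min-1.g-1. The difference between the core of compound 1 and the core of compound 2 is not broken down here.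

The change methyl in place of hydrogen on a saturated chain carbon, two bonds along the chain from an aromatic carbon and two fluorine atoms gives a step that the two limits leave unreadable from compound 2 to compound 3, since both compounds sit at the limit of < 5 mL.min-1.g-1 in this assay, at which 2 of the 3 values shown sit.

Compound 4, `Cc1cc(Nc2ccc(Cl)cc2)n2nc(C(C)C)nc2n1`, is not yet measured in this assay. It differs from compound 1 by methyl in place of hydrogen on a saturated chain carbon bound to an aromatic carbon and a saturated chain carbon. This is the same kind of change as from compound 2 to compound 3, but the surroundings differ: here the carbon is bound to an aromatic carbon and a saturated chain carbon, whereas there it lies two bonds along the chain from an aromatic carbon and two fluorine atoms.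

For compound 4 a step of a 1.1-fold higher number from compound 1 to compound 4 (0.04 log units; within the scatter) is expected, resting on compound 1 at 12.8 mL.min-1.g-1, because the measured step that the two limits leave unreadable from compound 2 to compound 3 is not readable in size and gives no direction. The estimate for compound 4 in this assay is 14 mL.min-1.g-1, between 6 mL.min-1.g-1 and 35 mL.min-1.g-1.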

Compound 4, intrinsic clearance in microsomes in the Homo sapiens assay: 14.1 mL.min-1.g-1
For compound 4 the middle estimate is 1.0-fold (0.00 log units) below the measured one, and the stated range covers the measured number.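

In the Homo sapiens assay compound 1 gives 12.8 mL.min-1.g-1, compound 4 gives 14.1 mL.min-1.g-1, and the ethyl to isopropyl change on the core of compound 1 gives a 1.1-fold higher number from compound 1 to compound 4 (0.04 log units; within the scatter), so on this core the two clearance numbers cannot be told apart. The same kind of change on the other core, at a carbon with different surroundings, gives a step that cannot be read, since compound 2 and compound 3 each give only a limit of the assay: the limit of < 5 mL.min-1.g-1 in the Homo sapiens assay, at which 2 of the 4 values shown sit. The series therefore holds one readable case, which shows that the methyl made no clear difference on one core but does not show that this result carries from one core to another.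

In a physicochemical assay for solubility, at pH 6.5 (a higher number here means a more soluble compound, a lower number a less soluble compound), compound 1 gives 170000 nM, compound 4 gives 83000 nM, and the same change gives a 2.0-fold lower number from compound 1 to compound 4 (0.31 log units; beyond the scatter). On these data alone, whether a step of this kind also appears on the other core remains open. The compounds shown also leave open how clearance and solubility respond when the alkyl arm carries an amine, a hydroxyl group or a longer chain.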